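Capping the hydroxyl: ether side chain variation on a naphthoquinone scaffold

A few compounds are considered here, and "the series" means these few. Any claim that something is new, unique, unknown or untested is made for them only; others in the source may bear on it.

Compound 1 `CCC(C)(O)CC(=O)O[C@H](CC=C(C)C)C1=CC(=O)c2c(O)ccc(O)c2C1=O` gives 16000 nM in a functional assay on DU-145 cells (Homo sapiens) for cytotoxicity, read by MTT assay; a lower number here means a stronger inhibitor, a higher number a weaker inhibitor. Compound 2 `CC(C)=CC[C@@H](OC[C@H](C)O)C1=CC(=O)c2c(O)ccc(O)c2C1=O` gives 24500 nM. Compound 3 `CC(C)=CC[C@@H](OC(=O)CC(C)(O)c1ccccc1)C1=CC(=O)c2c(O)ccc(O)c2C1=O` reaches only a limit of the assay, > 100000 nM. Compound 4 `CCC(CO[C@H](CC=C(C)C)C1=CC(=O)c2c(O)ccc(O)c2C1=O)OC(C)=O` is not yet measured.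

Compound 2 stands at the higher of the two numbers reported, though the step of a 1.5-fold higher number from compound 1 to compound 2 (0.19 log units; within the scatter) puts it within the scatter of compound 1, so no order between them can be read. The other measured step, an at least 6.2-fold higher number from compound 1 to compound 3 (0.79 log units; beyond the scatter), shows a weakening beyond the scatter, and one of the three values sits at the limit of > 100000 nM in this assay, at which 1 of the 3 values shown sits.

Compound 4 differs from compound 2 at the side chain on the oxygen: 1-acetoxypropyl in place of 1-hydroxyethyl on a saturated chain carbon bound to an oxygen on a saturated carbon. Neither measured step covers this change. The step from compound 1 to compound 2 swapped an ester for an ether bearing a hydroxyl without moving beyond the scatter, which suggests this part of the molecule tolerates variation; the step to compound 3 added a phenyl, a much larger change than the acetylation and chain extension here. Compound 4 is therefore expected to stay near compound 2, with a 1.2-fold higher number from compound 2 to compound 4 (0.09 log units; within the scatter) as the estimated step. The estimate for compound 4 is 30000 nM, within 10000 nM to 100000 nM.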

Compound 4, half-maximal inhibitory concentration: 25400 nM
For compound 4 the middle estimate is 1.2-fold (0.07 log units) above the measured one, and the stated range covers the measured number.
By their numbers in this assay, from the lowest: compounds 1, 2 and 4 (each within the scatter of the next). At a limit, above all of these: compound 3.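

In this assay, compound 4 is the only one of the compounds shown whose side chain carries no free hydroxyl: 1-hydroxyethyl, with its hydrogen-bond donor, gives way to 1-acetoxypropyl, with 0 hydrogen-bond donors. Even so, the result is a 1.0-fold higher number from compound 2 to compound 4 (0.02 log units; within the scatter) and, against the ester of compound 1, a 1.6-fold higher number from compound 1 to compound 4 (0.20 log units; within the scatter), so at this place on a saturated chain carbon bound to an oxygen on a saturated carbon, neither the loss of the hydroxyl nor the larger group separates these compounds, and a free hydroxyl on the side chain is not needed to stay at this level. Nothing given here explains why the number holds, and the one available note, on the limit reached by compound 3, does not bear on this change.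

The change capped the hydroxyl and lengthened the chain in one step, so the compounds shown cannot say what each does alone, or whether the two offset each other. They also leave open how a side chain ending in an amine or a carboxylic acid would read at this place, and whether any group here could give a number clearly lower than those of compound 1, compound 2 and compound 4.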